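Methyl to chloro on the fused pyrazinone core: extraction expectation

This account rests on a few compounds, and the source may have more. Where it says the series, first, only, none or still open, it means among the compounds named here.

Measured compounds:
- compound 1 `CC[C@H](C)n1c(=O)[nH]c2ncc(Br)nc21`: 0.3
- compound 2 `CCC(CC)n1c(=O)[nH]c2nccnc21`: "not determined" (no result reported)
- compound 3 `CCC(CC)n1c(=O)[nH]c2ncc(C)nc21`: 0.7

For the measured compounds named here, in an ADME assay on microsomes from liver (Rattus norvegicus), read by LC-MS, with a stated time of 90 min (on this read-out higher numbers stand for higher hepatic extraction and lower numbers for lower hepatic extraction), compound 3 gives 0.7, the highest of the two numbers in hand; compound 1 gives 0.3, a gap beyond the scatter, though compound 1 differs from compound 3 in two places, so no single step is drawn. Compound 2 has no result.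

Compound 4 `CCC(CC)n1c(=O)[nH]c2ncc(Cl)nc21` differs from compound 3 by chloro in place of methyl on an aromatic carbon. Going by the values given here, no measured pair isolates this exchange. Among the compounds with values here, the only halogen-bearing compound, compound 1, sits low at 0.3, so a decrease is expected for compound 4, but its extent is uncertain and a value within the scatter of compound 3 cannot be excluded. The expected step is a number 0.20 lower from compound 3 to compound 4 (beyond the scatter). Compound 4 is estimated at 0.5, with a range from 0.3 to 0.7.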

Compound 4, hepatic extraction ratio: 0.4
For compound 4 the middle estimate is 0.10 above the measured one; the range from low to high includes it.
By their numbers in this assay, from the lowest: compounds 1 and 4 (each within the scatter of the next); then compound 3.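

Chloro in place of methyl on the aromatic carbon next to the ring nitrogen is the first single-place comparison in the series: in this assay it gives a number 0.30 lower from compound 3 to compound 4 (beyond the scatter) with the rest of the structure unchanged. Hepatic extraction therefore responds to the group at this position, at least for this exchange. Nothing measured here accounts for the step.

Open, from the compounds shown here alone, is how a methoxy group, a nitrile or an amine on this carbon would compare with methyl and chloro. Also open, going by these compounds, is whether this step holds with a different chain on the shared core.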